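Shortening a charged side chain on a bradykinin antagonist

The source may hold more compounds than are shown below. What is called first, only, known or untested is meant among the compounds shown, and "the series" means these compounds.

Of the compounds shown here, three built on one shared core have been tested in an assay on isolated protein for binding affinity to B1 bradykinin receptor (Homo sapiens); on this read-out lower numbers stand for stronger inhibition and higher numbers for weaker inhibition. Compound 1 `Cc1cc(C)c2cccc(OCc3c(Cl)ccc(S(=O)(=O)NC4(C(=O)N5CCN(C(=O)[C@@H](N)CCCC[N+](C)(C)C)CC5)CCCC4)c3Cl)c2n1` carries its charged side chain on a carbonyl carbon. In this assay compound 1 returns only a limit of the assay, < 10000 nM, not a number. Compound 2 `Cc1cc(C)c2cccc(OCc3c(Cl)ccc(S(=O)(=O)NC4(C(=O)N5CCN(C(=O)C[C@@H](N)CCC[N+](C)(C)C)CC5)CCCC4)c3Cl)c2n1` likewise gives only a limit, < 10000 nM. Compound 3 `Cc1cc(C)c2cccc(OCc3c(Cl)ccc(S(=O)(=O)NC4(C(=O)N5CCN(C(=O)C[C@H](CCCN)[N+](C)(C)C)CC5)CCCC4)c3Cl)c2n1` also stops at a limit, < 10000 nM. Compound 3 therefore stands exactly where the other two stand: at the edge of what the assay reports, with no finite value. For the same reason the steps a step that the two limits leave unreadable from compound 1 to compound 2, a step that the two limits leave unreadable from compound 1 to compound 3 and a step that the two limits leave unreadable from compound 2 to compound 3 cannot be given a size, and the whole of the evidence is the limit of < 10000 nM in this assay, at which 3 of the 3 values shown sit.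

Compound 4 `Cc1cc(C)c2cccc(OCc3c(Cl)ccc(S(=O)(=O)NC4(C(=O)N5CCN(C(=O)[C@@H](N)CC[N+](C)(C)C)CC5)CCCC4)c3Cl)c2n1` is reached from compound 3 by a group of 8 heavy atoms (6 carbon, 2 nitrogen; no ring) in place of a group of 10 heavy atoms (8 carbon, 2 nitrogen; no ring), on a carbonyl carbon. Going by the values given here, since none of the measured steps has a readable size, no direction beyond the usual scatter can be expected for this change; the expected step is a step that the limit leaves unreadable from compound 3 to compound 4, one that stays within the scatter. Compound 4 is therefore expected to sit near the same limit, and is estimated at 3000 nM, with a likely range from 300 nM to 10000 nM.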

Compound 4, inhibition constant: < 10000 nM
Compound 4: no number, only a limit (the forecaster's own chance of this, stated with the estimate: 60%); the middle value does not contradict the limit.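

Compound 4, like compound 1, compound 2 and compound 3, returns only a limit of the assay and not a number, so none of its steps to those compounds can be given a size: the limit of < 10000 nM in this assay, at which 4 of the 4 values shown sit.

The compounds shown leave open how strongly each one actually binds in this assay, and whether the shorter side chain of compound 4 changes that at all.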